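The source may report more compounds than this note shows. Statements on the series, on what has been measured and on what is new or still open speak of the compounds shown alone.

Measured so far in a physicochemical assay for lipophilicity, using the shake flask method; a higher number here means a more lipophilic compound, a lower number a more polar compound:
- Compound 1 `C[C@H](Oc1ccc2ncc(/C=C/C(=O)O)c(C#N)c2c1)c1c(Cl)ccc(F)c1Cl`: 2.3
- Compound 2 `C[C@H](Oc1ccc(/C=C/C(=O)O)cc1)c1c(Cl)ccc(F)c1Cl`: 2.8

Of these two compounds, compound 1 has the lower number, and the gap between them lies beyond the usual scatter of repeated measurements.

The next compound to be measured is compound 3 `C[C@H](Oc1ccc2ncc(/C=C/C(=O)O)c(N(C)C)c2c1)c1c(Cl)ccc(F)c1Cl`. It keeps the core of compound 1 and changes one group: dimethylamino in place of cyano on an aromatic carbon. That carbon is ortho to a 2-carboxyethenyl group and opposite the ring nitrogen.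

Going by the values given here, no measured pair here shows a swap of this kind, so the data give no direct guide to its size. The expectation is therefore a judgement made from the two groups alone, and it starts from compound 1 at 2.3. A modest rise in this assay is expected. The estimated change is a number 0.40 log units higher from compound 1 to compound 3 (beyond the scatter), which would lie just beyond the scatter. With so little to go on, the range is kept wide, and its lower end allows for no real change at all. For compound 3, the expected value is 2.7, within an estimated range of 2.1 to 3.3.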

Compound 3, distribution coefficient: 3.6
Beside the measured number, compound 3's estimate is 0.90 log units below it, and the stated range ends below it.
By their numbers in this assay, from the lowest: compound 1; then compound 2; then compound 3.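

In this assay, putting dimethylamino in place of cyano on this aromatic carbon, ortho to a 2-carboxyethenyl group and opposite the ring nitrogen, gives a number 1.30 log units higher from compound 1 to compound 3 (beyond the scatter), a large step. Going by these compounds alone, the earlier compounds offered no pair differing in one place, so this is the first sign that the group on this carbon can, on its own, shift the number so far, even though cyano and dimethylamino match in their counted hydrogen-bond donors and acceptors and neither carries a net charge. Nothing measured here bears on why the step is this large.

On these data alone, it remains open whether a simple amino group, a methoxy group or a longer diethylamino group on the same carbon would give a step of similar size, which would show how much depends on dimethylamino itself. Also open, as far as these compounds go, is whether the same swap would give a similar step if a methyl ester took the place of the carboxylic acid in the 2-carboxyethenyl group.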